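The compounds below may be only part of what the source reports. "The series", "measured", "known", "first", "only" and "open" are said of these compounds alone.

Working notes on the series. The shared core appears in compound 1 `COc1cc(-c2nnc3n2NC(c2ccco2)C(C(=O)c2ccccc2C)S3)cc(OC)c1OC`, compound 2 `COc1cc(-c2nnc3n2NC(c2ccco2)C(C(=O)c2ccc(Br)cc2)S3)cc(OC)c1OC` and compound 3 `COc1cc(-c2nnc3n2NC(c2ccco2)C(C(=O)C2CC2)S3)cc(OC)c1OC`. In a functional assay on A549 cells (Homo sapiens) for cytotoxicity, read by MTT assay, with a stated time of 48 h (a lower number here means a stronger inhibitor, a higher number a weaker inhibitor), compound 1 gives 80000 nM and compound 2 gives 42100 nM, with the step of a 1.9-fold lower number from compound 1 to compound 2 (0.28 log units; within the scatter). Compound 3 stands only at the assay limit, > 100000 nM, which is a bound and not a number (the limit of > 100000 nM in this assay, at which 1 of the 3 values shown sits). Compound 4 `COc1cc(-c2nnc3n2NC(c2ccco2)C(C(=O)c2ccc(C)cc2)S3)cc(OC)c1OC` differs from compound 3 by 4-methylphenyl in place of cyclopropyl on a carbonyl carbon. The two measured steps that bear on this run the other way, an at least 1.2-fold higher number from compound 1 to compound 3 (0.09 log units; that floor lies within the scatter) and an at least 2.3-fold higher number from compound 2 to compound 3 (0.37 log units; beyond the scatter), both moving toward the limit when cyclopropyl replaces an aryl group; reversing that change is expected to bring the number back into the measurable range. For compound 4 the expected step is an at least 2.0-fold lower number from compound 3 to compound 4 (0.30 log units; that floor lies within the scatter), giving an estimate of 50000 nM, between 20000 nM and 100000 nM.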

Compound 4, half-maximal inhibitory concentration: > 100000 nM
Compound 4 ended at the assay's limit (the forecaster's own chance of this, stated with the estimate: 25%); at least 2.0-fold (0.30 log units) between middle value and limit.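

An aryl group on this carbonyl carbon does not by itself bring the number into the measurable range, and the choice of substituent on the ring now shows an effect, with an at least 2.3-fold higher number from compound 2 to compound 4 (0.37 log units; beyond the scatter) when methyl replaces bromo on an aromatic carbon. Moving from 2-methylphenyl to 4-methylphenyl gives an at least 1.2-fold higher number from compound 1 to compound 4 (0.09 log units; that floor lies within the scatter), so that change is not resolved. The step between compound 3 and compound 4 cannot be read: the limit of > 100000 nM in this assay, at which 2 of the 4 values shown sit.

Still open, as far as these compounds go, is whether chloro, methoxy or an amine in place of bromo on that aromatic carbon would give a measurable number.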